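The compounds below may be only part of what the source reports. "The series", "measured", "known", "first", "only" and "open" are said of these compounds alone.

Measured so far in a functional assay on LoVo cells (Homo sapiens) for inhibition, read by MTT assay, with a stated time of 48 h; a higher number here means a weaker inhibitor, a lower number a stronger inhibitor:
- compound 1 (`COc1ccc(N(C)c2nc(C)nc3ccccc23)cc1C(=O)OCCC[Se]C#N`): 854 nM
- compound 2 (`Cc1nc(N(C)c2ccc([Se]C#N)c(Cl)c2)c2ccccc2n1`): 12 nM

Compound 1 has the higher number of the two, and its gap to compound 2 lies beyond the scatter. Compound 3 (`COc1ccc(N(C)c2nc(C)nc3ccccc23)cc1`) differs from compound 1 by a single change: a hydrogen atom in place of a group of 9 heavy atoms (5 carbon, 1 nitrogen, 2 oxygen, 1 selenium; no ring), on an aromatic carbon. Within the data shown here, no measured pair shows the effect of such a change, so the expectation rests on thin evidence. Still, compound 2 reaches 12 nM, which shows that a far lower number is possible in this assay. A drop beyond the scatter is therefore expected, an estimated 85-fold lower number from compound 1 to compound 3 (1.93 log units; beyond the scatter). Compound 3 is estimated at 10 nM, with an expected range from 2 nM to 80 nM.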

Compound 3, half-maximal inhibitory concentration: 8 nM
For compound 3 the middle estimate is 1.3-fold (0.10 log units) above the measured one; measured number inside the range.
By their numbers in this assay, from the lowest: compounds 3 and 2 (each within the scatter of the next); then compound 1.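

Among these compounds, putting a hydrogen atom in place of the group of 9 heavy atoms, on the aromatic carbon ortho to a methoxy group, gives a 110-fold lower number from compound 1 to compound 3 (2.03 log units; beyond the scatter) in this assay, the first view of a change at this position. The core of compound 1 therefore needs neither this chain nor its selenium to give a low number in this assay. Nothing measured here explains the size of this step.

Whether the whole chain or only one part of it accounts for the step remains open. So does the effect of a small group at this position, such as an amine or a carboxylic acid.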